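From Chloro to Hydroxy in an Antiproliferative Pair

The compounds below may be only part of what the source reports. "The series", "measured", "known", "first", "only" and "open" are said of these compounds alone.

For the measured compounds named here, in a functional assay on A549 cells (Homo sapiens) for antiproliferative activity, read by MTT assay, with a stated time of 48 h (a higher number here means a weaker inhibitor, a lower number a stronger inhibitor), two compounds sharing one core have numbers so far. Compound 1 (`COc1cc(/C=C/c2nnc(NC(=O)c3ccccc3Br)s2)c(Br)c(OC)c1OC`) gives 210 nM, and compound 2 (`COc1cc(/C=C/c2nnc(NC(=O)c3cccc(Cl)c3)s2)c(Br)c(OC)c1OC`) gives 70 nM, the lower of the two and beyond the scatter of the other. Compound 3 (`COc1cc(/C=C/c2nnc(NC(=O)c3cccc(O)c3)s2)c(Br)c(OC)c1OC`) has not yet been measured. It differs from compound 2 as follows: hydroxy in place of chloro on an aromatic carbon. Hydroxy stands in place of chloro on an aromatic carbon, meta to a large group, so that 3-chlorophenyl becomes 3-hydroxyphenyl.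

Going by the values given here, no measured step makes this exact exchange. Among the compounds with values here, the only guide is a 3.0-fold lower number from compound 1 to compound 2 (0.48 log units; beyond the scatter), which swaps 2-bromophenyl for 3-chlorophenyl on a carbonyl carbon, in the same part of the molecule. With that modest step as the only size available, a step of similar modest size is expected. Within the data shown here, the direction is uncertain, but compound 2 at 70 nM holds the lowest number so far, so a higher number is the weak expectation. The estimated change is a 2.3-fold higher number from compound 2 to compound 3 (0.36 log units; beyond the scatter). For compound 3 the expected value is 160 nM, with an estimated range of 45 nM to 550 nM.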

Compound 3, half-maximal inhibitory concentration: 120 nM
Compound 3: middle estimate off by 1.3-fold (0.12 log units), on the high side; low and high end bracket the measured number.
By their numbers in this assay, from the lowest: compounds 2, 3 and 1 (each within the scatter of the next, the first and the last beyond it).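

In this assay the exchange of chloro for hydroxy on this aromatic carbon, meta to a large group, comes to a 1.7-fold higher number from compound 2 to compound 3 (0.23 log units; within the scatter) and so does not separate the two compounds, even though the entering hydroxy brings one hydrogen-bond donor and one hydrogen-bond acceptor where the chloro counted none. The 3-hydroxyphenyl compound also cannot be separated from the 2-bromophenyl compound, with a 1.8-fold lower number from compound 1 to compound 3 (0.24 log units; within the scatter) as the listed step, whereas the earlier pair stood apart by a 3.0-fold lower number from compound 1 to compound 2 (0.48 log units; beyond the scatter) and so gave no sign that a change on this ring could leave the number within the scatter. Nothing measured here accounts for this small step, so the result stands as an observation without an explanation.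

With a single exchange at this position, the compounds shown cannot establish a general pattern for groups placed here. Going by these compounds, it remains open whether a methoxy, an amine or a carboxylic acid on the same aromatic carbon would also stay within the scatter of compound 2 or would move the number beyond it.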